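A few compounds are considered here, and "the series" means these few. Any claim that something is new, unique, unknown or untested is made for them only; others in the source may bear on it.

Measured compounds:
- compound 1, `Cc1ccccc1-c1nn(-c2ccc(F)cc2F)cc1CNCCN1CCCCC1`: in an ADME assay on Huh-7 cells (Homo sapiens) for cytotoxicity (a lower number here means that less compound is tolerated, a higher number that more compound is tolerated), compound 1 gives > 20000 nM
- compound 2, `Cc1ccccc1-c1nn(-c2ccc(OC(F)(F)F)cc2)cc1CNCCN1CCN(C)CC1`: in this assay compound 2 gives 17000 nM
- compound 3, `CCCN1CCC(CNCc2cn(-c3ccc(C(F)(F)F)cc3)nc2-c2ccc(OC(F)(F)F)cc2)CC1`: in this assay compound 3 gives 2200 nM

The value for compound 1 is a limit of the assay and not a number. Compound 1 is the one of the three that sits at the limit of > 20000 nM in this assay, at which 1 of the 3 values shown sits, so where it stands is known only as a floor: more compound was tolerated than the assay could report. Compound 2 and compound 3 both give numbers, and the number for compound 3 is lower than the number for compound 2.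

Compound 4, `CCN(CC)CCCNCc1cn(-c2ccc(F)cc2F)nc1-c1ccccc1C`, has not yet been measured in this assay. It differs from compound 1 in one place: (diethylamino)methyl in place of piperidin-1-yl on a saturated chain carbon, two bonds along the chain from an amine nitrogen. Put differently, one six-membered non-aromatic ring with 1 hetero atom leaves and a group with no ring enters, while the count of heavy atoms, hydrogen-bond donors and hydrogen-bond acceptors stays the same. Among the measured compounds shown here, no measured pair among the three compounds shows this kind of change, so the expectation rests on compound 1 alone. The step from compound 1 to compound 4 in this assay is expected to be a number no higher from compound 1 to compound 4 (the limit leaves the size open), that is, nothing beyond the usual scatter in either direction. Compound 4 is therefore expected to give about 20000 nM, within a range from 8000 nM to 50000 nM.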

Compound 4, half-maximal cytotoxic concentration: > 20000 nM
Compound 4 gave a limit, no number; the forecaster's own chance of this, stated with the estimate: 55%; the middle value lies on the limit itself.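

In this assay, among the compounds shown here, compound 4 gives a limit and not a number, just as compound 1 does, so no step between compound 1 and compound 4 can be read: the limit of > 20000 nM in this assay, at which 2 of the 4 values shown sit. The compounds shown leave open how much of compound 1 and compound 4 is tolerated, and whether (diethylamino)methyl in place of piperidin-1-yl changes that at all.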